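Ring Nitrogen Substituents: Pyridyl to Benzoate Ester Swap

The source may hold more compounds than are shown below. What is called first, only, known or untested is meant among the compounds shown, and "the series" means these compounds.

The series keeps one shared core and varies only the group attached to the aromatic nitrogen. Compound 1 `CCOC(=O)c1c(C)nc(-c2cccc(C#N)c2)n1C(C)C` bears isopropyl there; in a functional assay on a cell-free system (plasma, Oryctolagus cuniculus) for inhibition, with stated times of 5 min, 1 min and 6 min (on this read-out lower numbers stand for stronger inhibition and higher numbers for weaker inhibition), compound 1 gives 9260 nM. Compound 2 `CCOC(=O)c1c(C)nc(-c2cccc(C#N)c2)n1OC(C)C` carries isopropoxy in place of isopropyl on the aromatic nitrogen, and compound 2 gives 6740 nM; the step is a 1.4-fold lower number from compound 1 to compound 2 (0.14 log units; within the scatter). Compound 3 `CCOC(=O)c1c(C)nc(-c2cccc(C#N)c2)n1OCc1ccncc1` carries (pyridin-4-yl)methoxy, and compound 3 gives 6200 nM. Compound 3 stands level with both neighbours: a 1.5-fold lower number from compound 1 to compound 3 (0.17 log units; within the scatter) and a 1.1-fold lower number from compound 2 to compound 3 (0.04 log units; within the scatter) are each within the scatter, so none of the three separates from the others on this read-out.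

Compound 4 `CCOC(=O)c1c(C)nc(-c2cccc(C#N)c2)n1OCc1ccc(C(=O)OC)cc1` differs from compound 3 by 4-(methoxycarbonyl)phenyl in place of pyridin-4-yl on a saturated chain carbon bound to an oxygen on an aromatic ring. Among the measured compounds shown here, no measured step exchanges one aromatic ring for another at this place, so there is no direct precedent. For the measured compounds named here, the only guide is that every change made so far on the aromatic nitrogen, whether a 1.4-fold lower number from compound 1 to compound 2 (0.14 log units; within the scatter) or a 1.1-fold lower number from compound 2 to compound 3 (0.04 log units; within the scatter), stayed within the scatter. The expectation for compound 4 in this assay is therefore no step beyond the scatter in either direction. Compound 4 is expected at 6000 nM, with a range from 2500 nM to 15000 nM, corresponding to an expected step of a 1.0-fold lower number from compound 3 to compound 4 (0.01 log units; within the scatter).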

Compound 4, half-maximal inhibitory concentration: 9470 nM
Beside the measured number, compound 4's estimate is 1.6-fold (0.20 log units) below it; measured number inside the range.
By their numbers in this assay, from the lowest: compounds 3, 2, 1 and 4 (each within the scatter of the next).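

Among the compounds shown here, exchanging pyridin-4-yl for 4-(methoxycarbonyl)phenyl on a saturated chain carbon bound to an oxygen on an aromatic ring is the first change of one aromatic ring for another at this place, and in this assay it gives a 1.5-fold higher number from compound 3 to compound 4 (0.18 log units; within the scatter). For this pair, then, neither the loss of the ring nitrogen nor the entry of a carbon-only ring carrying a methoxycarbonyl group moves the number beyond the scatter, so the hetero atom of pyridin-4-yl is not needed to keep the read-out level with compound 3. No accompanying measurement bears on this result, so nothing can be stated about what lies behind the step.

All the steps shown at this place stay within the scatter, so it remains open whether any group here can move the number beyond it in either direction. A carboxylic acid in place of the methoxycarbonyl group, an amine on the carbon-only ring, or a longer chain between the oxygen and the ring would test that question directly.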